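The compounds below may be only part of what the source reports. "The series", "measured", "known", "first", "only" and "open" are said of these compounds alone.

Measured so far:
compound 1 `Cn1cc(-c2n[nH]c3ccc(N[C@@H]4CCNC4)cc23)cn1`, 37000 nM
compound 2 `Cn1cc(-c2n[nH]c3cc(Cl)c(Br)cc23)cn1`, 850 nM

In an assay on isolated protein for inhibition of tyrosine-protein kinase receptor UFO (Homo sapiens), with a stated time of 1.5 h (on this read-out lower numbers stand for stronger inhibition and higher numbers for weaker inhibition), compound 1 gives 37000 nM, the higher of the two numbers measured; compound 2 gives 850 nM, a gap beyond the scatter. The shared core of compound 1 is kept in compound 3 `Cn1cc(-c2n[nH]c3ccc(Nc4ccccc4)cc23)cn1`, and the change is phenyl in place of pyrrolidin-3-yl on a nitrogen on an aromatic ring. Among the measured compounds shown here, no measured pair shows this kind of change, so the expectation rests on the sense that a flat aromatic ring in place of a saturated one may shift the number moderately downward, and the step from compound 1 to compound 3 is estimated at a 3.1-fold lower number from compound 1 to compound 3 (0.49 log units; beyond the scatter). Compound 3 is therefore expected to give about 12000 nM, within a range from 2500 nM to 50000 nM.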

Compound 3, half-maximal inhibitory concentration: 580 nM
Compound 3: middle estimate off by 21-fold (1.32 log units), on the high side; the whole stated range lies above it.
By their numbers in this assay, from the lowest: compounds 3 and 2 (each within the scatter of the next); then compound 1.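

On a nitrogen on an aromatic ring, phenyl in place of pyrrolidin-3-yl gives a 64-fold lower number from compound 1 to compound 3 (1.80 log units; beyond the scatter). Among the compounds shown here, this shows that the group at this position can change the number by a large amount, which the earlier compounds could not show because they differ in more than one place. No measurement here explains the size of this step.

Going by these compounds, it remains open whether the gain comes from the aromatic ring itself or from losing the ring nitrogen. Cyclopentyl on the same nitrogen, or a phenyl carrying an amine, would help separate these possibilities.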